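A few compounds are considered here, and "the series" means these few. Any claim that something is new, unique, unknown or untested is made for them only; others in the source may bear on it.

Among the compounds with values here, the three compounds measured so far share one core and differ only in the group attached to the carbonyl carbon of the amide. Compound 1 `Cc1nc(C(=O)Nc2ccc(Cl)c(-c3nnc4c(Cl)cccn34)c2)cs1` carries a 2-methyl-1,3-thiazol-4-yl group, and in a functional assay on HeLa cells (Homo sapiens) for antiproliferative activity, read by MTT assay, with a stated time of 72 h (on this read-out higher numbers stand for weaker inhibition and lower numbers for stronger inhibition), compound 1 gives 79800 nM. Compound 2 `O=C(Nc1ccc(Cl)c(-c2nnc3c(Cl)cccn23)c1)c1ccc(C(F)(F)F)cc1F` carries a phenyl group bearing fluoro and trifluoromethyl substituents, and in this assay compound 2 gives 61900 nM. Compound 3 `O=C(Nc1ccc(Cl)c(-c2nnc3c(Cl)cccn23)c1)c1ccc(Cl)cc1Cl` carries a 2,4-dichlorophenyl group. In this assay compound 3 gives no number but only a limit, > 100000 nM. Within the data shown here, the only one-point step among the measured compounds is an at least 1.2-fold higher number from compound 1 to compound 3 (0.09 log units; that floor lies within the scatter), and its size cannot be fixed more closely because of the limit of > 100000 nM in this assay, at which 1 of the 3 values shown sits. Compound 4 `O=C(Nc1ccc(Cl)c(-c2nnc3c(Cl)cccn23)c1)c1ccccc1Cl` is reached from compound 3 by hydrogen in place of chloro on an aromatic carbon. Among the measured compounds shown here, no measured step removes a chloro from this ring, so the expectation rests on the crowding of all three measured values at weak inhibition and on the limit of compound 3. Compound 4 is therefore expected to remain a weak inhibitor, with a step of a number no higher from compound 3 to compound 4 (the limit leaves the size open) that stays within the scatter. The estimate for compound 4 in this assay is 100000 nM, between 45000 nM and 250000 nM.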

Compound 4, half-maximal inhibitory concentration: > 100000 nM
Compound 4 was reported as a limit (the forecaster's own chance of this, stated with the estimate: 50%); the middle value lies on the limit itself.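

In this assay compound 4 gives > 100000 nM, which is a limit and not a number: with the 2,4-dichlorophenyl group cut back to 2-chlorophenyl, the series still yields no measurable value at this position. The change itself cannot be sized, and the step between compound 3 and compound 4 stays unreadable because both values are limits: the limit of > 100000 nM in this assay, at which 2 of the 4 values shown sit. Set against the 2-methyl-1,3-thiazol-4-yl group, the 2-chlorophenyl group gives an at least 1.2-fold higher number from compound 1 to compound 4 (0.09 log units; that floor lies within the scatter), so this comparison fixes only a floor and shows no difference beyond the usual variation between repeated measurements.

The compounds shown leave open whether compound 3 and compound 4 differ at all, since neither has a value that can be placed on the scale. They also leave open whether a plain phenyl ring, or a ring carrying a methoxy group or an amine in place of the remaining chloro, would give a number clear of the limit.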